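Chloro Substitution on Two Related Amide Cores

The source may report more compounds than this note shows. Statements on the series, on what has been measured and on what is new or still open speak of the compounds shown alone.

Of the compounds shown here, three of the study have been measured in a functional assay on HeLa cells (Homo sapiens) for inhibition; a lower number here means a stronger inhibitor, a higher number a weaker inhibitor. Compound 1, `CCN(CC)CCNC(=O)CC(CC(=O)NC1Cc2ccccc2C1)c1ccc(Cl)cc1`, gives in this assay a value of 50500 nM. Compound 2, `CCN(CC)CCNC(=O)CC(CC(=O)NC1Cc2ccccc2C1)c1ccccc1`, reaches in this assay only the limit of the assay, > 100000 nM. Compound 3, `CN(C(=O)CC(CC(=O)NCCN1CCCC1)c1ccccc1)C1Cc2ccccc2C1`, likewise reaches in this assay only the limit, > 100000 nM. The difference between the core of compound 2 and the core of compound 3 is not broken down here.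

Within the first core, the change chloro in place of hydrogen on an aromatic carbon gave an at least 1.9-fold lower number from compound 2 to compound 1 (0.29 log units; that floor lies within the scatter). The size of that step is known only as a floor because compound 2 sits at the limit of > 100000 nM in this assay, at which 2 of the 3 values shown sit.

Compound 4, `CN(C(=O)CC(CC(=O)NCCN1CCCC1)c1ccc(Cl)cc1)C1Cc2ccccc2C1`, has not yet been measured. It carries the same change on the second core: chloro in place of hydrogen on an aromatic carbon. The place of the change reads the same in both pairs, so it is the same change on a different core. Since compound 3 sits at the limit as well, the expectation for compound 4 rests on the floor set by compound 2 and compound 1 alone. Compound 4 is therefore expected to show an at least 1.6-fold lower number from compound 3 to compound 4 (0.22 log units; that floor lies within the scatter) in this assay, with a real chance that the assay again reports only a limit. The estimate for compound 4 in this assay is 60000 nM, between 25000 nM and 150000 nM.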

Compound 4, half-maximal inhibitory concentration: 55400 nM
Compound 4: middle estimate off by 1.1-fold (0.03 log units), on the high side; the range from low to high includes it.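

On the second core, the phenyl to 4-chlorophenyl change gave in this assay an at least 1.8-fold lower number from compound 3 to compound 4 (0.25 log units; that floor lies within the scatter) and so repeated what was seen on the first core: the chloro compound returned a measured number, while its partner without chloro did not. Compound 2 and compound 3 both stand at a limit of the assay, not at a number: the limit of > 100000 nM in this assay, at which 2 of the 4 values shown sit. The result therefore shows that the change can be carried from one core to the other in direction, as far as these two pairs go, but it does not show that it is worth the same amount on both, and each floor lies within the scatter, so neither step is firmly established on its own: the same change on two cores in this assay, an at least 1.9-fold lower number (0.29 log units; that floor lies within the scatter) from compound 2 to compound 1 and an at least 1.8-fold lower number (0.25 log units; that floor lies within the scatter) from compound 3 to compound 4; the limit leaves it open whether they differ.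

The compounds shown leave open whether another group at the same place on the six-membered aromatic ring, such as fluoro, methoxy or trifluoromethyl, would read the same way on either core. They also leave open how much of the behaviour belongs to the chain carrying the terminal amine, since a longer chain or a different amine at that end does not appear among them.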